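Removing One Methoxy Group from Compound 2

The compounds below may be only part of what the source reports. "The series", "measured", "known", "first", "only" and "open" are said of these compounds alone.

Measured compounds:
compound 1 `COc1ccc(-c2cc(/C=C/C(=O)c3ccc(N)cc3)[nH]n2)cc1`: -75%
compound 2 `COc1cc(-c2cc(/C=C/C(=O)c3ccc(N)cc3)[nH]n2)cc(OC)c1OC`: -85%

In a functional assay on MDA-MB-435 cells (Homo sapiens) for cytotoxicity, read by sulforhodamine B assay, with a stated time of 48 h, tested at 100 uM (on this read-out higher numbers stand for a weaker effect at the one concentration tested and lower numbers for a stronger effect), compound 1 gives -75% and compound 2 gives -85%. Compound 2 has the lowest of these two numbers, yet the number for compound 1 lies within the usual scatter, so no order can be read from them. Compound 3 `COc1ccc(-c2cc(/C=C/C(=O)c3ccc(N)cc3)[nH]n2)cc1OC` differs from compound 2 in one place: hydrogen in place of methoxy on an aromatic carbon. Going by the values given here, no step between measured compounds is available to gauge this change. The step expected from compound 2 to compound 3 is a number 5 percentage points higher from compound 2 to compound 3 (within the scatter), no change beyond the scatter. Compound 3 is therefore estimated to give -80%, with a range from -95% to -60%.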

Compound 3, a percentage reported as activity, at one concentration (the size of the read-out at that concentration, not a potency): -72%
The estimate for compound 3 lay 8 percentage points below the measured number, within the range that was stated.
By their numbers in this assay, from the lowest: compounds 2, 1 and 3 (each within the scatter of the next, the first and the last beyond it).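

In this assay, going by these compounds alone, taking this one methoxy group off compound 2 gives a number 13 percentage points higher from compound 2 to compound 3 (beyond the scatter), a modest weakening of the effect and the first change here that stands clear of the scatter. Putting a methoxy group onto compound 1 gives a number 3 percentage points higher from compound 1 to compound 3 (within the scatter), so that addition shows no readable effect, and the methoxy group matters only in the compound carrying the fuller set. As far as these compounds go, whether an amine or a hydroxyl group on this aromatic carbon would match methoxy remains open. No evidence at hand gives a reason for the step from compound 2.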